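The source may report more compounds than this note shows. Statements on the series, on what has been measured and on what is new or still open speak of the compounds shown alone.

Three compounds built on one shared core were examined in an ADME assay on RAW264.7 cells (Mus musculus) for cytotoxicity, read by MTT assay, with a stated time of 24 h; a lower number here means that less compound is tolerated, a higher number that more compound is tolerated. Compound 1 `Cc1ccc(C2=NN(C3=NC(=O)CS3)C(c3ccc(Br)cc3)C2)cc1C` gives 365000 nM. Compound 2 `Cc1ccc(C2=NN(C3=NC(=O)CS3)C(c3ccccc3)C2)cc1C` gives > 450000 nM, which is a limit of the assay rather than a number. That value stands at the limit of > 450000 nM in this assay, at which 1 of the 3 values shown sits. Compound 3 `O=C1CSC(N2N=C(c3ccc(Cl)c(Cl)c3)CC2c2ccccc2)=N1` gives 295000 nM. The core of compound 3 differs from that of compound 2 in one place, (3,4-dichlorophenyl in place of 3,4-dimethylphenyl on a carbon with a double bond to nitrogen), and that change made a step of an at least 1.5-fold lower number from compound 2 to compound 3 (0.18 log units; that floor lies within the scatter). The change from compound 2 to compound 1 is bromo in place of hydrogen on an aromatic carbon, and it made a step of an at least 1.2-fold lower number from compound 2 to compound 1 (0.09 log units; that floor lies within the scatter).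

Compound 4 `O=C1CSC(N2N=C(c3ccc(Cl)c(Cl)c3)CC2c2ccc(Br)cc2)=N1` has not yet been measured in this assay. It differs from compound 3 by bromo in place of hydrogen on an aromatic carbon, the same change as from compound 2 to compound 1, now made on the core of compound 3, which carries 3,4-dichlorophenyl where compound 2 carries 3,4-dimethylphenyl. Because the earlier step rests on compound 2 giving > 450000 nM, only its floor is known, and that floor lies within the scatter. For compound 4 a step of a 1.2-fold lower number from compound 3 to compound 4 (0.07 log units; within the scatter) is therefore expected, small and pointing downward. Compound 4 is thus estimated at 250000 nM, with a likely range from 120000 nM to 450000 nM.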

Compound 4, half-maximal cytotoxic concentration: 280000 nM
The estimate for compound 4 lay 1.1-fold (0.05 log units) below the measured number; low and high end bracket the measured number.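

In this assay, bromo in place of hydrogen on an aromatic carbon gave a 1.1-fold lower number from compound 3 to compound 4 (0.02 log units; within the scatter), and 3,4-dichlorophenyl in place of 3,4-dimethylphenyl gave a 1.3-fold lower number from compound 1 to compound 4 (0.12 log units; within the scatter), so neither change moved the number beyond the scatter on its new core. This does not show that the bromo change carries over with the same size, nor that its size differs between the two cores: the same change on two cores in this assay, an at least 1.2-fold lower number (0.09 log units; that floor lies within the scatter) from compound 2 to compound 1 and a 1.1-fold lower number (0.02 log units; within the scatter) from compound 3 to compound 4; the limit leaves it open whether they differ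

The same holds for the change from 3,4-dimethylphenyl to 3,4-dichlorophenyl: the same change on two cores in this assay, an at least 1.5-fold lower number (0.18 log units; that floor lies within the scatter) from compound 2 to compound 3 and a 1.3-fold lower number (0.12 log units; within the scatter) from compound 1 to compound 4; the limit leaves it open whether they differ

The compounds shown leave open whether a different group in place of the bromo, such as an amine or a carboxylic acid, would move the number beyond the scatter. Going by these compounds, compound 2 gives > 450000 nM, a limit of the assay and not a number, and the full size of the two steps that start from it also stays open.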